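Swapping the benzamide aryl: bromine out, nitro in

A few compounds are considered here, and "the series" means these few. Any claim that something is new, unique, unknown or untested is made for them only; others in the source may bear on it.

Compound 1 `NC(=O)c1c(NC(=O)c2ccccc2Cl)sc2c1CCN(Cc1ccc(Cl)cc1Cl)C2` gives 8010 nM in a functional assay on HL-60 cells (Homo sapiens) for antiproliferative activity, with a stated time of 24 h; on this read-out lower numbers stand for stronger inhibition and higher numbers for weaker inhibition.
Compound 2 `Cc1ccc(C(=O)Nc2sc3c(c2C(N)=O)CCN(Cc2ccc(Cl)cc2Cl)C3)cc1` gives 19900 nM in this assay.
Compound 3 `NC(=O)c1c(NC(=O)c2ccccc2Br)sc2c1CCN(C(=S)Nc1ccccc1Cl)C2` gives 14600 nM in this assay.

Compound 3 holds the second highest of the three numbers, but its gaps to compound 2 and to compound 1 both lie within the scatter, so the three cannot be ranked against one another. Compound 4 `NC(=O)c1c(NC(=O)c2cccc([N+](=O)[O-])c2)sc2c1CCN(C(=S)Nc1ccccc1Cl)C2` differs from compound 3 in one place: 3-nitrophenyl in place of 2-bromophenyl on a carbonyl carbon. Within the data shown here, the only measured step at the same carbonyl carbon is a 2.5-fold higher number from compound 1 to compound 2 (0.40 log units; beyond the scatter), a different exchange of aryl groups and a modest one. Among the measured compounds shown here, no measured step exchanges a bromine for a nitro group. Compound 4 is therefore expected to stay close to compound 3, with a 1.0-fold higher number from compound 3 to compound 4 (0.01 log units; within the scatter), and no shift beyond the scatter is foreseen. The estimate for compound 4 is 15000 nM, ranging from 6000 nM to 40000 nM.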

Compound 4, half-maximal inhibitory concentration: 7040 nM
The estimate for compound 4 lay 2.1-fold (0.33 log units) above the measured number, within the range that was stated.
By their numbers in this assay, from the lowest: compounds 4, 1, 3 and 2 (each within the scatter of the next, the first and the last beyond it).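

Exchanging 2-bromophenyl for 3-nitrophenyl on a carbonyl carbon gives a 2.1-fold lower number from compound 3 to compound 4 (0.32 log units; beyond the scatter) in this assay. Among these compounds, this position therefore responds to an aryl exchange with a lower number as well, whereas the only earlier step there, a 2.5-fold higher number from compound 1 to compound 2 (0.40 log units; beyond the scatter), went the other way and belonged to a different group on the far side of the shared core. Nothing available accounts for this step.

As far as these compounds go, whether the drop follows the nitro group, the loss of bromine or the changed place on the phenyl ring stays open, since these changed together. How an amine or a carboxylic acid on that phenyl ring would read is also unknown.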